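Two ring stereocentres inverted in the saturated core

The source may hold more compounds than are shown below. What is called first, only, known or untested is meant among the compounds shown, and "the series" means these compounds.

Of the compounds shown here, three have been measured in an ADME assay (liver) for metabolic stability, with Liver microsome (Rattus norvegicus) as the target, using microsomes, with a stated time of 30 min; a higher number here means that more of the compound is left, a lower number that less of the compound is left. Compound 1 `COC(=O)N[C@H](C(=O)N1CCC[C@H]1C(=O)Nc1ccc([C@H]2CC[C@H](c3ccc(NC(=O)[C@@H]4CCCN4C(=O)[C@@H](NC(=O)OC)C(C)C)cc3)N2c2ccc(C(F)(F)F)cc2)cc1)C(C)C` gives 58% in this assay. Compound 2 `COC(=O)N[C@H](C(=O)N1CCC[C@H]1C(=O)Nc1ccc([C@H]2CC[C@H](c3ccc(NC(=O)[C@@H]4CCCN4C(=O)[C@@H](NC(=O)OC)C(C)(C)C)cc3)N2c2ccc(F)cc2)cc1)C(C)(C)C` gives 69% in this assay. Compound 3 `COC(=O)N[C@H](C(=O)N1CCC[C@H]1C(=O)Nc1ccc([C@@H]2CC[C@@H](c3ccc(NC(=O)[C@@H]4CCCN4C(=O)[C@@H](NC(=O)OC)C(C)C)cc3)N2c2ccc(F)cc2)cc1)C(C)C` gives 49% in this assay, the lowest of the three numbers; the gap to compound 1 lies within the scatter of repeated measurements, while the gap to compound 2 lies beyond it. For the measured compounds named here, no two of the measured compounds differ in a single place, so no step between measured compounds is available as a guide.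

Compound 4 `COC(=O)N[C@H](C(=O)N1CCC[C@H]1C(=O)Nc1ccc([C@H]2CC[C@H](c3ccc(NC(=O)[C@@H]4CCCN4C(=O)[C@@H](NC(=O)OC)C(C)C)cc3)N2c2ccc(F)cc2)cc1)C(C)C` is not yet measured. Relative to compound 3 it changes as follows: the two compounds have the same atoms and bonds and differ only in configuration as drawn: 2 of 6 stereo elements differ; a stereocentre at a saturated ring carbon is drawn S in compound 3 and R in compound 4; a stereocentre at a saturated ring carbon is drawn S in compound 3 and R in compound 4. Nothing leaves and nothing enters; the two compounds have the same atoms and bonds and differ only in configuration as drawn.

With no measured step of this kind in hand, the expectation is a step from compound 3 to compound 4 that stays within the scatter, with no preferred direction beyond it; a step of a number 6 percentage points higher from compound 3 to compound 4 (within the scatter) is estimated. Compound 4 is therefore expected to give about 55% in this assay, with an estimated range from 40% to 70%.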

Compound 4, percent of the compound remaining: 38%
Compound 4: the middle estimate sits 17 percentage points above what was measured; the measured number lies below the stated range.
By their numbers in this assay, from the lowest: compound 4; then compounds 3 and 1 (each within the scatter of the next); then compound 2.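

In this assay the two saturated ring carbons of the shared core now stand as a position where configuration alone counts, with a number 11 percentage points lower from compound 3 to compound 4 (beyond the scatter) and no atom or bond changed. For the compounds shown here, this step can be placed on those two stereocentres and on nothing else, a reading that no pair among the earlier compounds offered, none of them differing in a single place: the fact that compounds 3 and 4 differ only in the configuration as drawn. The substituent on the aromatic ring attached to the core nitrogen also gets its first single-place reading, with fluoro in place of trifluoromethyl on an aromatic carbon giving a number 20 percentage points lower from compound 1 to compound 4 (beyond the scatter) in the configuration that compound 1 and compound 4 share.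

The compounds shown leave open whether that substituent step holds in the configuration of compound 3, and whether one of the two stereocentres carries the configuration step or both share it. As far as these compounds go, how a nitrile or a methoxy group on the same aromatic carbon would compare with fluoro and trifluoromethyl also stays open.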